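Swapping the phenol for a fluorophenyl on the thiosemicarbazone

The source may report more compounds than this note shows. Statements on the series, on what has been measured and on what is new or still open speak of the compounds shown alone.

The series shares the core of compound 1 `CC1=CC[C@H](C(C)(C)NC(=S)NN)CC1`, which in a functional assay on NCI-H460 cells (Homo sapiens) for inhibition, read by sulforhodamine B assay, with a stated time of 48 h (on this read-out higher numbers stand for weaker inhibition of growth and lower numbers for stronger inhibition of growth), gives 42000 nM. Compound 2 `CC1=CC[C@H](C(C)(C)NC(=S)N/N=C/c2ccccc2)CC1` gives 13000 nM in this assay. For compound 3 `CC1=CC[C@H](C(C)(C)NC(=S)N/N=C/c2ccc(O)cc2)CC1` the this assay reports only a limit, > 100000 nM. Within the data shown here, compound 3 thus sits at the limit of > 100000 nM in this assay, at which 1 of the 3 values shown sits, and the step of an at least 7.6-fold higher number from compound 2 to compound 3 (0.88 log units; beyond the scatter) is the only measured step that bears on what follows. Compound 4 `CC1=CC[C@H](C(C)(C)NC(=S)N/N=C/c2ccc(F)cc2)CC1` differs from compound 3 by fluoro in place of hydroxy on an aromatic carbon, that is 4-hydroxyphenyl to 4-fluorophenyl. Since the hydroxy that entered in an at least 7.6-fold higher number from compound 2 to compound 3 (0.88 log units; beyond the scatter) leaves again here, a modest move back toward the number of compound 2 is expected, the fluoro adding an unknown. Compound 4 is therefore estimated at 20000 nM, between 7000 nM and 60000 nM, an expected step of an at least 5.0-fold lower number from compound 3 to compound 4 (0.69 log units; beyond the scatter).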

Compound 4, concentration for 50% growth inhibition: > 100000 nM
Compound 4: a limit, no number (the forecaster's own chance of this, stated with the estimate: 20%); middle value at least 5.0-fold (0.69 log units) away from the limit.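

In this assay, fluoro in place of hydrogen on the aromatic carbon para to a large group gives an at least 7.6-fold higher number from compound 2 to compound 4 (0.88 log units; beyond the scatter). Hydroxy is therefore not the only group at this position to carry the number past that of compound 2. The result for compound 4 is a limit and not a number, and the step from compound 3 cannot be read: the limit of > 100000 nM in this assay, at which 2 of the 4 values shown sit.

As far as these compounds go, how far compound 3 and compound 4 lie beyond the limit remains open. So does whether a methyl, chloro or methoxy group at this position would give a readable number.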